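From 3-aminopropyl to 2-aminoethyl in a cytotoxicity test

This account rests on a few compounds, and the source may have more. Where it says the series, first, only, none or still open, it means among the compounds named here.

Compound 1 (`NCCCNC(=O)[C@@]12C[C@@H]1[C@@H](n1cnc3c(NC(C4CC4)C4CC4)nc(Cl)nc31)[C@H](O)[C@@H]2O`) has been examined in an ADME assay on Vero 76 cells (Chlorocebus sabaeus) for cytotoxicity, read by microscopy; on this read-out lower numbers stand for higher toxicity in this test and higher numbers for lower toxicity in this test. Compound 1 gives > 50000 nM, and this value is a limit, not a number. Among the measured compounds shown here, only one other compound has been measured, compound 2 (`CC(C)(O)[C@@H](Nc1nc(Cl)nc2c1ccn2[C@H]1[C@H](O)[C@H](O)[C@]2(CO)C[C@H]12)C1CC1`). Compound 2 gives > 100000 nM, which is likewise a limit. For the measured compounds named here, compound 1 therefore stands at a limit, and neither measured compound has an exact value, so the data offer no measured step to serve as a guide.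

The next compound, compound 3 (`NCCNC(=O)[C@@]12C[C@@H]1[C@@H](n1cnc3c(NC(C4CC4)C4CC4)nc(Cl)nc31)[C@H](O)[C@@H]2O`), differs from compound 1 in one place: amino in place of aminomethyl on a saturated chain carbon, two bonds along the chain from an amide-type nitrogen. This puts amino in place of aminomethyl on a saturated chain carbon, two bonds along the chain from an amide-type nitrogen. Read one bond further out, the same difference is 3-aminopropyl to 2-aminoethyl.

No change beyond the usual scatter is expected in this assay, and no direction is favoured. The estimated step is a step that the limit leaves unreadable from compound 1 to compound 3. This expectation rests on compound 1, whose > 50000 nM is a limit. A report of compound 3 as a limit alone would therefore be no surprise. For compound 3 the estimated value is 55000 nM, with an expected range from 25000 nM to 100000 nM.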

Compound 3, half-maximal cytotoxic concentration: > 50000 nM
Compound 3: no number, only a limit (the forecaster's own chance of this, stated with the estimate: 75%); the middle value lies beyond the limit too.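

In this assay compound 3 gives > 50000 nM, which is a limit and not a number. Compound 1 also stands at a limit, so no step can be read from compound 1 to compound 3. The compounds shown leave open how the 3-aminopropyl and 2-aminoethyl compounds compare in this assay, as neither has an exact value.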